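Thiophene for tolyl on the sulfonamide: leucine boronic acids

The compounds below may be only part of what the source reports. "The series", "measured", "known", "first", "only" and "open" are said of these compounds alone.

Measured so far in a functional assay on A549 cells (Homo sapiens) for antiproliferative activity, read by sulforhodamine B assay, with a stated time of 72 h; a lower number here means a stronger inhibitor, a higher number a weaker inhibitor:
compound 1, `Cc1ccc(S(=O)(=O)Nc2cc(SCCC(=O)N[C@@H](CC(C)C)B(O)O)c(O)c3ccccc23)cc1`, gives 8190 nM
compound 2, `CC(C)C[C@H](NC(=O)CCSc1cc(NS(=O)(=O)c2cccs2)c2ccccc2c1O)B(O)O`, gives 5930 nM
compound 3, `Cc1ccc(S(=O)(=O)Nc2cc(SC(C)C(=O)N[C@@H](CC(C)C)B(O)O)c(O)c3ccccc23)cc1`, gives 7280 nM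

Compound 2 differs from compound 1 by thiophen-2-yl in place of 4-methylphenyl on a sulfonyl sulfur; the step is a 1.4-fold lower number from compound 1 to compound 2 (0.14 log units; within the scatter). Compound 3 has the same atoms as compound 1 joined differently; the difference between the two cores is not broken down here, and the values of compound 1 and compound 3 lie within the scatter of each other.

Compound 4, `CC(C)C[C@H](NC(=O)C(C)Sc1cc(NS(=O)(=O)c2cccs2)c2ccccc2c1O)B(O)O`, is not yet measured. It differs from compound 3 by thiophen-2-yl in place of 4-methylphenyl on a sulfonyl sulfur, the same change at the same place as between compound 1 and compound 2. Resting on the step of a 1.4-fold lower number from compound 1 to compound 2 (0.14 log units; within the scatter), the expected step is a 1.4-fold lower number from compound 3 to compound 4 (0.14 log units; within the scatter). Compound 4 is expected at 5300 nM in this assay. The range for compound 4 is expected to run from 2500 nM to 11000 nM.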

Compound 4, half-maximal inhibitory concentration: 11300 nM
Beside the measured number, compound 4's estimate is 2.1-fold (0.33 log units) below it; measured number above the stated range.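

Thiophen-2-yl in place of 4-methylphenyl on a sulfonyl sulfur gives a 1.6-fold higher number from compound 3 to compound 4 (0.19 log units; within the scatter) in this assay. Set beside the earlier step, the new one gives no sign that the two cores respond differently: the same change on two cores in this assay, a 1.4-fold lower number (0.14 log units; within the scatter) from compound 1 to compound 2 and a 1.6-fold higher number (0.19 log units; within the scatter) from compound 3 to compound 4, 2.1-fold (0.33 log units) apart, within the scatter of two such steps

Both steps lie within the scatter, so this pair of cores shows no measurable effect of the change on either one, but it does not prove that the two groups are equivalent or that the change would behave the same way on other cores.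

Other groups on the sulfonyl sulfur, such as methyl or pyridinyl, remain open. So do a carboxylic acid in place of the boronic acid and a longer chain from the ring sulfur to the amide carbonyl.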